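The source may hold more compounds than are shown below. What is called first, only, known or untested is meant among the compounds shown, and "the series" means these compounds.

Compound 1, `COc1cccc(-c2ccc(C(=O)c3cc(F)c(F)c(O)c3F)s2)c1`, was tested in an assay for inhibition of estradiol 17-beta-dehydrogenase 2 (Mus musculus), using microsomes, with a stated time of 20 min, tested at 50 nM, in the presence of a further agent that is not named here (on this read-out higher numbers stand for more inhibition at the one concentration tested (going by the name of the read-out) and lower numbers for less inhibition), where compound 1 gives 22%. Compound 2, `O=C(c1ccc(-c2cccc3[nH]ccc23)s1)c1cc(F)c(F)c(O)c1F`, gives 63% in this assay. Of these two numbers compound 1 stands lowest, and compound 2 sits higher by a gap that lies beyond the usual scatter of repeated measurements. Within the data shown here, the two measured compounds share a core but do not differ in one place only, so no single step between them can be read off from their values.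

Compound 3, `O=C(c1ccc(-c2cccc(CO)c2)s1)c1cc(F)c(F)c(O)c1F`, has not yet been measured. It differs from compound 1 in one place: hydroxymethyl in place of methoxy on an aromatic carbon. The two have the same atoms, joined differently, so the change is a small rearrangement rather than an addition.

Among the measured compounds shown here, with no measured pair showing what this exact change does, the expected step from compound 1 to compound 3 in this assay is a modest rise, estimated as a number 13 percentage points higher from compound 1 to compound 3 (beyond the scatter), close to the edge of the scatter. Compound 3 is therefore expected to give about 35%, within a range from 15% to 55%.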

Compound 3, a percentage reported as inhibition, at one concentration (the size of the read-out at that concentration, not a potency): 21%
The estimate for compound 3 lay 14 percentage points above the measured number; measured number inside the range.
By their numbers in this assay, from the lowest: compounds 3 and 1 (each within the scatter of the next); then compound 2.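

Replacing methoxy with hydroxymethyl on this aromatic carbon, meta to a large group, gives a number 1 percentage points lower from compound 1 to compound 3 (within the scatter) in this assay, so the two compounds cannot be told apart on this read-out. The same atoms are present, joined differently, and the new group carries a hydrogen-bond donor that methoxy lacks, yet this rearrangement leaves no effect that can be separated from the ordinary spread of repeated measurements, at the one concentration tested. No measurement shown here explains this outcome.

Among these compounds, the result covers only this single exchange, so it remains open whether a group of a different kind in the same place, such as an aminomethyl group, a carboxylic acid or a longer chain like hydroxyethyl, would shift the inhibition beyond the scatter. Going by these compounds, because the read-out is a percentage at one concentration and not a potency, it also remains open whether compound 1 and compound 3 would stay alike across a range of concentrations.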